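A few compounds are considered here, and "the series" means these few. Any claim that something is new, unique, unknown or untested is made for them only; others in the source may bear on it.

Compound 1 `COc1cc(Cl)cc(-c2nn(-c3cccc(NC(=O)Nc4ccc(Cl)c(Cl)c4)c3)cc2-c2ccncc2)c1` and compound 2 `COc1cc(Cl)cc(-c2nn(-c3cccc(NC(=O)Nc4cccc(C(F)(F)F)c4)c3)cc2-c2ccncc2)c1` share one core and differ only in the aryl group on the amide-type nitrogen. In a functional assay on OVCAR-4 cells (Homo sapiens) for inhibition, read by sulforhodamine B assay, with a stated time of 48 h, tested at 100 uM (a lower number here means a stronger effect, a higher number a weaker effect of the compound at the concentration tested), compound 1 gives -4%. Compound 2 gives -13% in this assay and so sits at the low end of the two numbers shown, although the step of a number 9 percentage points lower from compound 1 to compound 2 (within the scatter) lies within the scatter. Compound 3 `COc1cc(Cl)cc(-c2nn(-c3cccc(NC(=O)c4cccc(C(F)(F)F)c4)c3)cc2-c2ccncc2)c1` has not been measured. It differs from compound 2 by 3-(trifluoromethyl)phenyl in place of (3-(trifluoromethyl)phenyl)amino on a carbonyl carbon. Among the measured compounds shown here, the single measured step, a number 9 percentage points lower from compound 1 to compound 2 (within the scatter), exchanges one aryl group for another on the amide-type nitrogen and leaves the carbonyl carbon untouched, so no measured step bears directly on the present change; the two measured compounds only show that this series sits close to no effect. Compound 3 is therefore expected to give about -5% in this assay, between -25% and 15%, an estimated step of a number 8 percentage points higher from compound 2 to compound 3 (within the scatter) that stays within the scatter.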

Compound 3, a percentage reported as activity, at one concentration (the size of the read-out at that concentration, not a potency): 74%
Beside the measured number, compound 3's estimate is 79 percentage points below it, outside the stated range (above it).
By their numbers in this assay, from the lowest: compounds 2 and 1 (each within the scatter of the next); then compound 3.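

In this assay, the aryl exchange on the amide-type nitrogen had moved the number only within the scatter, but the link to the carbonyl carbon proves far more sensitive: a number 87 percentage points higher from compound 2 to compound 3 (beyond the scatter) when (3-(trifluoromethyl)phenyl)amino gives way to 3-(trifluoromethyl)phenyl. The result is similar when the comparison starts from the other aryl group, with a number 78 percentage points higher from compound 1 to compound 3 (beyond the scatter) in the same direction, and here a higher number means a weaker effect. Across these three compounds, therefore, the effect at the concentration tested follows the presence of the amino link more closely than the choice of aryl group. No measurement at hand explains the size of this step.

The compounds shown leave open whether the nitrogen itself or the amide hydrogen on it matters. A methylamino link, or an oxygen atom or a methylene group in the place of that nitrogen, could separate the two.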